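This account rests on a few compounds, and the source may have more. Where it says the series, first, only, none or still open, it means among the compounds named here.

Compound 1 (`CC(C)c1cc2c(cc1O)[C@]13CCC[C@](C)(CO[C@H]1O)[C@@H]3CC2`) was tested in a functional assay on Bel-7402 cells (Homo sapiens) for cytotoxicity, read by MTT assay, with a stated time of 24 h (on this read-out higher numbers stand for weaker inhibition and lower numbers for stronger inhibition), and gave > 10000 nM as its result, which is a limit of the assay and not a number. Compound 2 (`CO[C@@H]1OC[C@@]2(C)CCC[C@@]13c1cc(O)c(C(C)C)cc1CC[C@@H]23`) gave > 10000 nM in this assay as its result, and this too is only a limit. Compound 2 therefore stands at the limit of > 10000 nM in this assay, at which 2 of the 2 values shown sit, and has no number of its own.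

Compound 3 (`CCO[C@@H]1OC[C@@]2(C)CCC[C@@]13c1cc(O)c(C(C)C)cc1CC[C@@H]23`) departs from compound 2 in one place, methoxy to ethoxy (methyl in place of hydrogen on a saturated chain carbon bound to an oxygen on a saturated carbon), on a saturated chain carbon bound to an oxygen on a saturated carbon. Among the compounds with values here, the one measured step that bears on this is a step that the two limits leave unreadable from compound 1 to compound 2 and it was methyl in place of hydrogen on an oxygen on a saturated carbon. That step offers no size to carry over, so no change beyond the usual scatter is expected in this assay and no direction can be argued. The expected step is a step that the limit leaves unreadable from compound 2 to compound 3 and it is only an estimate. For compound 3 the estimated value is 20000 nM with an expected range from 8000 nM to 50000 nM and another limit is the likeliest report.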

Compound 3, half-maximal inhibitory concentration: > 10000 nM
Compound 3 ended at the assay's limit; the forecaster's own chance of this, stated with the estimate: 85%; the middle value does not contradict the limit.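

Compound 3, like compound 1 and compound 2, ended at a limit in this assay and not at a number, so no step among these three compounds can be read: the limit of > 10000 nM in this assay, at which 3 of the 3 values shown sit. The compounds shown leave open whether changing the group on this oxygen shifts the result at all, and how far each compound lies beyond the limit.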